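This account rests on a few compounds, and the source may have more. Where it says the series, first, only, none or still open, it means among the compounds named here.

The measured compounds:

compound 1 `OCCCCC#Cc1ccccc1C#Cc1ccccn1` with 29800 nM in a functional assay on HCT-15 cells (Homo sapiens) for cytotoxicity; a lower number here means a stronger inhibitor of growth, a higher number a weaker inhibitor of growth
compound 2 `OCCCCC#Cc1ccccc1C#Cc1cccs1` with 13100 nM
compound 3 `OCCCCC#Cc1ccccc1C#Cc1ccc(O)cc1` with 14100 nM

Compound 3 stands second highest of the three numbers; its value and that of compound 2 lie within the scatter of each other, as shown by a 1.1-fold higher number from compound 2 to compound 3 (0.03 log units; within the scatter), while compound 1 sits apart, the step being a 2.1-fold lower number from compound 1 to compound 3 (0.32 log units; beyond the scatter). Compound 4 `N#Cc1ccc(C#Cc2ccccc2C#CCCCCO)cc1` differs from compound 3 by cyano in place of hydroxy on an aromatic carbon. Among the compounds with values here, no measured step changes a substituent on the six-membered ring; the steps that exist swap whole rings, and all are modest: a 2.3-fold lower number from compound 1 to compound 2 (0.36 log units; beyond the scatter), a 2.1-fold lower number from compound 1 to compound 3 (0.32 log units; beyond the scatter) and a 1.1-fold higher number from compound 2 to compound 3 (0.03 log units; within the scatter). On that basis no step beyond the scatter in this assay is expected, that is a 1.0-fold lower number from compound 3 to compound 4 (0.00 log units; within the scatter). Compound 4 is therefore estimated at 14000 nM, with a range from 6000 nM to 35000 nM.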

Compound 4, concentration for 50% growth inhibition: 15600 nM
Compound 4: middle estimate off by 1.1-fold (0.05 log units), on the low side, within the range that was stated.
By their numbers in this assay, from the lowest: compounds 2, 3, 4 and 1 (each within the scatter of the next, the first and the last beyond it).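

Within the data shown here, this is the first measured change of a substituent rather than of a whole ring: with cyano in place of hydroxy, on an aromatic carbon para to a large group, this assay shows a 1.1-fold higher number from compound 3 to compound 4 (0.04 log units; within the scatter) in a step within the scatter. At this position, then, a hydrogen-bond donor leaves and a triple bond enters, yet the two numbers cannot be told apart. Nothing available explains this result.

On these data alone, whether an amine or a carboxylic acid on this same aromatic carbon would give a number beyond the scatter stays open. So does the effect of a longer chain on the shared core.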